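Moving two fluorines around a ring on a piperazine nitrogen

The source may hold more compounds than are shown below. What is called first, only, known or untested is meant among the compounds shown, and "the series" means these compounds.

Compound 2, with structure `Nc1scc(CN2CCN(c3cc(F)cc(F)c3)CC2)c1C(=O)c1ccc(Cl)cc1`, is the lower of the two measured compounds: in a functional assay on CHO cells with adenosine receptor A1 (Homo sapiens) as the target, read by cAMP accumulation and immunoassay, with a stated time of 6 min, tested at 1 uM (a higher number here means a weaker effect of the compound at the concentration tested, a lower number a stronger effect), compound 2 gives -66%, while compound 1, `Nc1scc(CN2CCN(c3cccc4ccccc34)CC2)c1C(=O)c1ccc(Cl)cc1`, gives 2.9%. Among the measured compounds shown here, the only measured step, a number 68.9 percentage points lower from compound 1 to compound 2 (beyond the scatter), shows that the group on this ring nitrogen matters greatly.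

Compound 3, `Nc1scc(CN2CCN(c3cccc(F)c3F)CC2)c1C(=O)c1ccc(Cl)cc1`, differs from compound 2 only in that the two fluorines sit elsewhere on the same ring: 2,3-difluorophenyl in place of 3,5-difluorophenyl on an amine nitrogen in a ring. For the measured compounds named here, no measured step shows what such a rearrangement of fluorines does here, so the one large step gives only a hint that the aryl group is sensitive, not a direction. A step of modest size is therefore expected, a number 31 percentage points higher from compound 2 to compound 3 (beyond the scatter), with wide uncertainty.

Compound 3 is estimated to give -35% in this assay, within a range from -85% to 15%.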

Compound 3, a percentage reported as activity, at one concentration (the size of the read-out at that concentration, not a potency): -66%
Beside the measured number, compound 3's estimate is 31 percentage points above it; measured number inside the range.
By their numbers in this assay, from the lowest: compounds 2 and 3 (each within the scatter of the next); then compound 1.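

Rearranging the two fluorines gives no change at the digits printed from compound 2 to compound 3 (within the scatter) in this assay, so for this pair the arrangement of the fluorines on the phenyl ring leaves the read-out at the single tested concentration unchanged. The replacement of naphthalen-1-yl also gives a number 68.9 percentage points lower from compound 1 to compound 3 (beyond the scatter), so the large step seen earlier is not tied to the 3,5-difluorophenyl group alone. No supporting information is available to explain these results.

The compounds shown leave open whether a plain phenyl ring, or a phenyl ring carrying a chlorine or a methoxy group, would read like compound 2 and compound 3 or like compound 1. They also leave open whether compound 2 and compound 3 would still match across a range of concentrations.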